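This account rests on a few compounds, and the source may have more. Where it says the series, first, only, none or still open, it means among the compounds named here.

In a functional assay on MCF7 cells (Homo sapiens) for antiproliferative activity, read by MTT assay, with a stated time of 48 h (a higher number here means a weaker inhibitor, a lower number a stronger inhibitor), compound 1 (`COc1ccc(/C=C/C=C\c2cc(OC)c(OC)c(OC)c2)cc1O`) gives 75 nM and compound 2 (`COc1cc(-c2nnc3c(OC4COC4)cc(-c4ccc5[nH]ccc5c4)cn23)cc(OC)c1OC`) gives 2470 nM as the higher of the two numbers, a gap beyond the usual scatter. Compound 3 (`COc1cc(-c2nnc3c(OC4CC4)cc(-c4ccc5[nH]ccc5c4)cn23)cc(OC)c1OC`) differs from compound 2 in one place (cyclopropyl in place of oxetan-3-yl on an oxygen on an aromatic ring) with cyclopropyl in place of oxetan-3-yl on an oxygen on an aromatic ring. For the measured compounds named here, no measured pair shows this change, so only a modest step (a 1.6-fold lower number from compound 2 to compound 3 (0.22 log units; within the scatter)) towards a lower number is expected, and it may stay within the scatter. Compound 3 is estimated at 1500 nM with an expected range from 400 nM to 6000 nM in this measurement.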

Compound 3, half-maximal inhibitory concentration: 259 nM
Estimate against measurement, compound 3: 5.8-fold (0.76 log units) above; the whole stated range lies above it.
By their numbers in this assay, from the lowest: compound 1; then compound 3; then compound 2.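

In this assay, the group on this oxygen clearly counts: going from oxetan-3-yl to cyclopropyl gives a step beyond the scatter (a 9.5-fold lower number from compound 2 to compound 3 (0.98 log units; beyond the scatter)). The swap is small, a four-membered ring with one hetero atom giving way to a three-membered ring of carbon only, yet it moves the number well past what was expected. Nothing available explains why this step is so large. Still open, as far as these compounds go, is how other groups on this oxygen would behave, such as a longer chain or a chain ending in an amine, and whether any would give a lower number than cyclopropyl.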